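Iodo in place of chloro on the shared core

This account rests on a few compounds, and the source may have more. Where it says the series, first, only, none or still open, it means among the compounds named here.

Compound 1 `Oc1nc(NCc2ccccc2)nc2ccc(Cl)cc12` has been measured in a functional assay (ileum) for inhibition, with Cavia porcellus as the target (on this read-out lower numbers stand for stronger inhibition and higher numbers for weaker inhibition), together with two close relatives. Compound 1 gives 13300 nM. Compound 2 `C[C@@H](Nc1nc(O)c2cc(Cl)ccc2n1)c1ccccc1` gives 20200 nM, and compound 3 `C[C@H](Nc1nc(O)c2cc(Cl)ccc2n1)c1ccccc1` gives 13200 nM. Among these three numbers compound 1 stands second highest, with compound 3 nearest and compound 2 furthest, and all three lie within the scatter of one another. The step of a 1.5-fold higher number from compound 1 to compound 2 (0.18 log units; within the scatter) adds a methyl to the chain carbon carrying the benzyl group, and the step of a 1.0-fold lower number from compound 1 to compound 3 (0.00 log units; within the scatter) adds the same methyl with the other drawn configuration. The gap a 1.5-fold lower number from compound 2 to compound 3 (0.18 log units; within the scatter) is also within the scatter, which fits (the fact that compounds 2 and 3 differ only in the configuration as drawn).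

Compound 4 `Oc1nc(NCc2ccccc2)nc2ccc(I)cc12` has not yet been measured in this assay. It differs from compound 1 by iodo in place of chloro on an aromatic carbon. For the measured compounds named here, none of the measured steps changes the halogen on the fused ring, so no measured step bears directly on this exchange, and every measured step in this assay was within the scatter. The step from compound 1 to compound 4 is therefore expected to stay within the scatter as well, that is a 1.0-fold lower number from compound 1 to compound 4 (0.01 log units; within the scatter). Compound 4 is estimated at 13000 nM, within a range from 5000 nM to 35000 nM.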

Compound 4, half-maximal inhibitory concentration: 8700 nM
Compound 4: middle estimate off by 1.5-fold (0.17 log units), on the high side, within the range that was stated.
By their numbers in this assay, from the lowest: compounds 4, 3, 1 and 2 (each within the scatter of the next, the first and the last beyond it).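

For the compounds shown here, the step of a 1.5-fold lower number from compound 1 to compound 4 (0.18 log units; within the scatter) in this assay is the first one here to touch the halogen on the shared core, since the earlier compounds all carry chloro and vary only at the chain carbon. It shows that iodo can stand in place of chloro on this aromatic carbon, meta to a fused ring and para to a fused ring, with a result that cannot be told apart from repeated measurements of a single compound, so this position joins the chain carbon as a second place where a single change has stayed within the scatter. Nothing known about these compounds explains how the two halogens compare at this position.

Still open, on these data alone, is whether this position would stay as undemanding with a different kind of group on the same aromatic carbon, such as fluoro, methoxy, an amine or a carboxylic acid, since two halogens are only a narrow sample of what could sit there. Also open, as far as these compounds go, is whether iodo would give the same picture on the methyl-bearing chains of compound 2 and compound 3, because the exchange has been read only on the benzyl chain of compound 1.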